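Aryl urea thienopyrimidines: methoxyphenyl isomer estimate

A few compounds are considered here, and "the series" means these few. Any claim that something is new, unique, unknown or untested is made for them only; others in the source may bear on it.

Measured so far in a functional assay on HepG2 cells (Homo sapiens) for antiproliferative activity, read by MTT assay, with a stated time of 48 h; on this read-out higher numbers stand for weaker inhibition and lower numbers for stronger inhibition:
compound 1 `Cc1ccc(NC(=O)Nc2nnc(Sc3ncnc4scc(-c5ccncc5)c34)s2)cc1Cl` gives 16000 nM
compound 2 `COc1ccc(NC(=O)Nc2nnc(Sc3ncnc4scc(-c5ccncc5)c34)s2)cc1` gives 14600 nM
compound 3 `Cc1ccc(NC(=O)Nc2nnc(Sc3ncnc4scc(-c5ccncc5)c34)s2)cc1` gives 52000 nM

Compound 2 has the lowest number of the three in this assay; its nearest neighbour is compound 1, at a 1.1-fold lower number from compound 1 to compound 2 (0.04 log units; within the scatter), and its furthest is compound 3, at a 3.6-fold higher number from compound 2 to compound 3 (0.55 log units; beyond the scatter).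

Compound 4 `COc1cccc(NC(=O)Nc2nnc(Sc3ncnc4scc(-c5ccncc5)c34)s2)c1` is not yet measured. It differs from compound 2 by 3-methoxyphenyl in place of 4-methoxyphenyl on an amide-type nitrogen; the atoms are the same, joined differently.

Within the data shown here, no measured step moves a group around the phenyl ring, so nothing bears on this change directly. Among the measured compounds shown here, two steps bear on it loosely. From compound 2 to compound 3 the methoxy is traded for methyl, a 3.6-fold higher number from compound 2 to compound 3 (0.55 log units; beyond the scatter), so the methoxy itself seems to matter on this ring. From compound 1 to compound 3 a chloro on the ring is removed, a 3.3-fold higher number from compound 1 to compound 3 (0.51 log units; beyond the scatter), so a second substituent beside the methyl on compound 1 helps by a modest amount. Both point to a substituted ring being tolerated, but neither says where the methoxy should sit. Given this, no step beyond the scatter is expected in this assay from compound 2 to compound 4; the expected step is a 1.1-fold higher number from compound 2 to compound 4 (0.04 log units; within the scatter), with a wide range.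

Compound 4 is estimated at 16000 nM, between 5000 nM and 50000 nM.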

Compound 4, half-maximal inhibitory concentration: 28400 nM
Compound 4: middle estimate off by 1.8-fold (0.25 log units), on the low side, and the stated range covers the measured number.
By their numbers in this assay, from the lowest: compounds 2, 1, 4 and 3 (each within the scatter of the next, the first and the last beyond it).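

In this assay, shifting the methoxy from 4-methoxyphenyl to 3-methoxyphenyl on the amide-type nitrogen gives a 1.9-fold higher number from compound 2 to compound 4 (0.29 log units; within the scatter), so this first reading of a group's place on the ring shows no effect that stands clear of the scatter. The new compound also cannot be grouped with either end of the series: the steps are a 1.8-fold lower number from compound 3 to compound 4 (0.26 log units; within the scatter) and a 1.8-fold higher number from compound 1 to compound 4 (0.25 log units; within the scatter), even though a 3.6-fold higher number from compound 2 to compound 3 (0.55 log units; beyond the scatter) separates those two ends. The series therefore tolerates the 3-methoxyphenyl group without a resolved change, and no measurement here offers an explanation for the values.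

On these data alone, whether an amine or a carboxylic acid in place of the methoxy would produce a step beyond the scatter remains open. Also open, as far as these compounds go, is whether a longer chain, such as ethoxy, would show a dependence on ring position that the two methoxyphenyl compounds do not resolve.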